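From compound 1 to compound 4: adding a methoxy

The source may hold more compounds than are shown below. What is called first, only, known or untested is meant among the compounds shown, and "the series" means these compounds.

In a functional assay on A549 cells (Homo sapiens) for cytotoxicity, read by MTT assay, with a stated time of 72 h (a higher number here means a weaker inhibitor, a lower number a stronger inhibitor), compound 1 (`O=C(Nc1nc2ccc(F)cc2s1)c1cn(-c2ccccc2)nc1-c1ccccc1`) gives 10200 nM, the lowest of the actual numbers in this small set. Compound 3 (`Cc1ccc2nc(NC(=O)c3cn(-c4ccccc4)nc3-c3ccccc3)sc2c1`) gives 26500 nM. Compound 2 (`COc1ccc2nc(NC(=O)c3cn(-c4ccccc4)nc3-c3ccccc3)sc2c1`) reads > 50000 nM, which is a limit of the assay and not a number.

Compound 4 (`COc1ccc(-c2nn(-c3ccccc3)cc2C(=O)Nc2nc3ccc(F)cc3s2)cc1`) has not yet been measured. It keeps the core of compound 1 but turns a phenyl into a 4-methoxyphenyl, a methoxy in place of hydrogen on an aromatic carbon. For the measured compounds named here, no measured step makes this exact change. The closest evidence comes from swaps at another place in the molecule, where a fluoro gave way to methoxy, an at least 4.9-fold higher number from compound 1 to compound 2 (0.69 log units; beyond the scatter), or to methyl, a 2.6-fold higher number from compound 1 to compound 3 (0.41 log units; beyond the scatter). Both raised the number, but each also removed a fluoro, so they are only a loose guide here.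

A modest rise is expected, with an estimated 2.0-fold higher number from compound 1 to compound 4 (0.29 log units; within the scatter). Compound 4 is expected near 20000 nM, with an estimated range of 8000 nM to 50000 nM.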

Compound 4, half-maximal inhibitory concentration: 7560 nM
The estimate for compound 4 lay 2.6-fold (0.42 log units) above the measured number; the whole stated range lies above it.
By their numbers in this assay, from the lowest: compounds 4 and 1 (each within the scatter of the next); then compound 3. At a limit, above all of these: compound 2.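

In this assay, turning the phenyl into a 4-methoxyphenyl gives a 1.3-fold lower number from compound 1 to compound 4 (0.13 log units; within the scatter), so the added methoxy makes no readable difference at this position, para to a large group. The swaps away from the fluoro, made at another place in the molecule, both raised the number beyond the scatter, so this is the first change from compound 1 shown to leave the number in place while adding heavy atoms. The compounds shown give no reason why a methoxy is accommodated here, and the one limit among the values has no bearing on this result.

One substituent at one position cannot show how much room for change this phenyl offers. As far as these compounds go, whether an amine, a carboxylic acid or a longer chain such as butoxy in the same place would also leave the number unmoved, or shift it in either direction, remains open.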